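Working notes: from compound 2 to compound 4

The compounds below may be only part of what the source reports. "The series", "measured", "known", "first", "only" and "open" are said of these compounds alone.

Measured compounds:
Compound 1 `O=C1CCCCC1S(=O)(=O)Nc1ccc(Cl)cc1C(F)(F)F` gives 21% in a functional assay on Bel-7402 cells (Homo sapiens) for antiproliferative activity, read by sulforhodamine B assay, tested at 100 ug/mL; a higher number here means more inhibition at the concentration tested (going by the name of the read-out), a lower number less inhibition.
Compound 2 `O=C1CCCCC1S(=O)(=O)Nc1ccc(Cl)cc1` gives 4.47%.
Compound 3 `O=C1CCCCC1S(=O)(=O)Nc1ccccc1Cl` gives 1.98%.

Compound 2 stands second highest of the three numbers in this assay; compound 3 sits within the scatter of it, compound 1 beyond the scatter above it. Compound 4 `O=C1CCCCC1S(=O)(=O)Nc1ccc(Cl)c(Cl)c1` differs from compound 2 by chloro in place of hydrogen on an aromatic carbon. Going by the values given here, the only single-place step measured is a number 16.5 percentage points lower from compound 1 to compound 2 (beyond the scatter), which concerns a different group and does not bear directly on a chloro entering. Compounds 2 and 3, which each carry one chloro, lie within the scatter of each other. Among the compounds with values here, with no measured step for a chloro entering, no change beyond the scatter is expected in this assay, a number 3.5 percentage points higher from compound 2 to compound 4 (within the scatter). Compound 4 is estimated at 8%, with a range from 0% to 22%.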

Compound 4, a percentage reported as inhibition, at one concentration (the size of the read-out at that concentration, not a potency): 1.39%
The estimate for compound 4 lay 6.6 percentage points above the measured number; the measured number falls inside the stated range.
By their numbers in this assay, from the lowest: compounds 4, 3 and 2 (each within the scatter of the next); then compound 1.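

In this assay, going by these compounds alone, chloro in place of hydrogen, ortho to a chloro group and meta to a large group, gives a number 3.1 percentage points lower from compound 2 to compound 4 (within the scatter) as the first measured step for a chloro entering. At this position, this change therefore gives no step beyond the scatter, unlike the loss of trifluoromethyl in a number 16.5 percentage points lower from compound 1 to compound 2 (beyond the scatter) on the same series. The data at hand offer no explanation for this result.
Still open, on these data alone, is whether an amine or a carboxylic acid on this same aromatic carbon would give a step beyond the scatter.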